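Swapping chloro for amino on the fused core

The source may report more compounds than this note shows. Statements on the series, on what has been measured and on what is new or still open speak of the compounds shown alone.

Measured so far:
- compound 1, `Nc1nn(C(=O)Nc2ccc(Cc3ccccc3)cc2)c2ccccc12`: > 100000 nM in a functional assay on DU-145 cells (Homo sapiens) for antiproliferative activity, read by sulforhodamine B assay, with a stated time of 48 h; on this read-out lower numbers stand for higher toxicity in this test and higher numbers for lower toxicity in this test
- compound 2, `Nc1nn(C(=O)Nc2ccc(Cc3ccccc3)cc2)c2ccc(Cl)cc12`: 80000 nM in this assay

In this assay compound 1 reaches only the limit of the measurement, recorded as > 100000 nM; that is the limit of > 100000 nM in this assay, at which 1 of the 2 values shown sits. Among the measured compounds shown here, compound 2 gives 80000 nM and holds the only true number among the two results. The step from hydrogen to chloro on an aromatic carbon came out as an at least 1.2-fold lower number from compound 1 to compound 2 (0.09 log units; that floor lies within the scatter).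

Compound 3, `Nc1ccc2c(c1)c(N)nn2C(=O)Nc1ccc(Cc2ccccc2)cc1`, differs from compound 2 by amino in place of chloro on an aromatic carbon. For the measured compounds named here, the only measured step that touches the same spot is the one from compound 1 to compound 2, and it stayed within the scatter. Nothing measured shows what an amino group does there, so no step beyond the scatter is expected in this assay, in either direction. For compound 3 the expected result is 90000 nM, within 25000 nM to 300000 nM, which means a step of a 1.1-fold higher number from compound 2 to compound 3 (0.05 log units; within the scatter) from compound 2 to compound 3 is expected, with a real chance that only a limit is reported.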

Compound 3, concentration lethal to 50% of the cells: 52600 nM
Compound 3: the middle estimate sits 1.7-fold (0.23 log units) above what was measured; measured number inside the range.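

In this assay the position on the six-membered aromatic ring has now carried a second kind of group, and chloro and amino there cannot be told apart: the swap gives a 1.5-fold lower number from compound 2 to compound 3 (0.18 log units; within the scatter). Amino brings a hydrogen-bond donor and a hydrogen-bond acceptor, which chloro lacks, yet this difference in the counts comes with no step that clears the scatter. Measured against hydrogen at the same spot, amino gives an at least 1.9-fold lower number from compound 1 to compound 3 (0.27 log units; that floor lies within the scatter), and that step can be read only as a floor because compound 1 carries a limit and not a true number: the limit of > 100000 nM in this assay, at which 1 of the 3 values shown sits.

Going by these compounds, what stays open is whether any group on this aromatic carbon can move the number beyond the scatter, and a carboxylic acid, a methoxy group or a longer chain such as propyl would each test that. Also open, on these data alone, is whether the swap of chloro for amino would read the same if a different group, such as a simple methyl, stood in place of the benzyl group on the far phenyl ring.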